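The compounds below may be only part of what the source reports. "The series", "measured", "known", "first", "only" and "open" are said of these compounds alone.

Compounds measured so far:
compound 1, `N#C/C(=C\N1CCN(C(=O)c2ccco2)C1=S)C(N)=O`: 23300 nM
compound 2, `O=CN1CCN(c2ccc(Cl)cc2)C1=S`: 17500 nM

The study follows a single step, from compound 2 to compound 3. In a functional assay on UACC-257 cells (Homo sapiens) for inhibition, read by sulforhodamine B assay, with a stated time of 48 h (a higher number here means a weaker inhibitor of growth, a lower number a stronger inhibitor of growth), compound 1 gives 23300 nM, and compound 2 gives 17500 nM. Compound 2 has the lowest of the two numbers, but its nearest neighbour, compound 1, sits within the scatter of it, so the two are not separable on what has been measured.

Compound 3, `O=CN1CCN(c2ccc(Cl)c(Cl)c2)C1=S`, has not yet been measured in this assay. It is compound 2 with chloro in place of hydrogen on an aromatic carbon. Among the measured compounds shown here, no measured pair shows what such a change does here, so there is nothing to lean on beyond the two values given. For the measured compounds named here, with only two compounds in hand, and those two within the scatter of each other, the step from compound 2 to compound 3 is expected to be modest, most likely toward a somewhat lower number, but a step of no size beyond the scatter would be unsurprising. The step is expected to be a 1.5-fold lower number from compound 2 to compound 3 (0.16 log units; within the scatter). Compound 3 is expected to give about 12000 nM, in the range 4000 nM to 35000 nM.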

Compound 3, concentration for 50% growth inhibition: 17700 nM
For compound 3 the middle estimate is 1.5-fold (0.17 log units) below the measured one; the measured number falls inside the stated range.
By their numbers in this assay, from the lowest: compounds 2, 3 and 1 (each within the scatter of the next).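

In this assay, chloro in place of hydrogen on an aromatic carbon, ortho to a chloro group and meta to a group of 8 heavy atoms, gives a 1.0-fold higher number from compound 2 to compound 3 (0.00 log units; within the scatter). Among the compounds shown here, this is the first single-place comparison, which the two earlier compounds could not provide because they differ in more than one place, and it shows that compound 2 and compound 3 cannot be told apart in this read-out. No measurement shown here offers an explanation for this result.

What the compounds shown leave open is whether a different group on this same aromatic carbon, such as an amine, a carboxylic acid or a methoxy group, would separate from compound 2 by more than the scatter. Going by these compounds, it also remains open whether chloro in place of hydrogen on the other aromatic carbons of the ring would give a step of similar size, since this single pair speaks only for the one position.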